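This account rests on a few compounds, and the source may have more. Where it says the series, first, only, none or still open, it means among the compounds named here.

Among the measured compounds shown here, in a functional assay on HeLa cells (Homo sapiens) for antiproliferative activity, read by CCK-8 assay, with a stated time of 72 h (a higher number here means a weaker inhibitor, a lower number a stronger inhibitor), compound 1 `COc1cc(-c2ncncc2-c2ccc(SC)cc2)cc(OC)c1OC` gives 220 nM and holds the lower, stronger number of the two measured so far. Compound 2 `COc1ccc(-c2cncnc2-c2cc(OC)c(OC)c(OC)c2)nc1` gives 470 nM in the same read-out. Compound 3 `COc1cc(-c2ncncc2-c2ccc(C(=O)N(C)C)cc2)cc(OC)c1OC` has not yet been measured. It keeps the core of compound 1 and carries dimethylcarbamoyl in place of methylsulfanyl on an aromatic carbon, para to a large group, a change counted as dimethylcarbamoyl in place of methylsulfanyl on an aromatic carbon here.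

For the measured compounds named here, only one measured step bears on this change, and it does so indirectly. That step, a 2.1-fold higher number from compound 1 to compound 2 (0.33 log units; beyond the scatter), also removes the methylsulfanyl group, but it replaces the whole 4-(methylsulfanyl)phenyl group with 5-methoxypyridin-2-yl. Going by the values given here, no measured compound carries dimethylcarbamoyl, so the data give only a direction and a loose sense of size. In this assay a move to a higher number, somewhat larger than that modest step, is therefore expected, and the expected change is a 3.6-fold higher number from compound 1 to compound 3 (0.56 log units; beyond the scatter) in this estimate. For compound 3 the estimated value is 800 nM, with an expected range from 230 nM to 3500 nM.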

Compound 3, half-maximal inhibitory concentration: 790 nM
Compound 3: the middle estimate sits 1.0-fold (0.01 log units) above what was measured, within the range that was stated.
By their numbers in this assay, from the lowest: compound 1; then compounds 2 and 3 (each within the scatter of the next).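

With the rest of the core of compound 1 kept in place, the exchange of methylsulfanyl for dimethylcarbamoyl on this aromatic carbon, para to a large group, gives in this assay a 3.6-fold higher number from compound 1 to compound 3 (0.56 log units; beyond the scatter) and so isolates the change at this one substituent. The earlier step replaced the whole 4-(methylsulfanyl)phenyl group, so it could not separate the substituent from the ring that carries it; this result shows that changing the substituent alone, with the six-membered aromatic ring of carbon only retained, is enough to move the number beyond the scatter, though the step is still modest. Nothing measured here accounts for this shift, so the result stands as an observation without an explanation.

The compounds shown leave open whether the higher number belongs to the amide as such or to the loss of the sulfur, which a methoxy group or an ethylsulfanyl group at the same place would help to separate. They also leave open how a primary carboxamide, a carboxylic acid or a methyl ester would read there, compared with dimethylcarbamoyl.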